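A few compounds are considered here, and "the series" means these few. Any claim that something is new, unique, unknown or untested is made for them only; others in the source may bear on it.

Measured in a physicochemical assay for solubility, in phosphate buffer, measured as kinetic solubility, with a stated time of 24 h, at pH 7.4; a higher number here means a more soluble compound, a lower number a less soluble compound:
- compound 1 `CC(C)CN(Cc1ccc(N2CCN(CS(C)(=O)=O)CC2)cc1)S(=O)(=O)Cc1ccccc1`: <= 1000 nM
- compound 2 `CC(C)CN(Cc1ccc(N2CCC(O)CC2)cc1)S(=O)(=O)Cc1ccccc1`: 7000 nM

The value of compound 1 is a limit, not a number. Within the data shown here, that leaves compound 2 with the only exact number in this assay. Compound 3 `COC1CCN(c2ccc(CN(CC(C)C)S(=O)(=O)Cc3ccccc3)cc2)CC1` carries methyl in place of hydrogen on an oxygen on a saturated carbon, hydroxy to methoxy (methyl in place of hydrogen on an oxygen on a saturated carbon). Among the measured compounds shown here, the only measured step, an at least 7.0-fold higher number from compound 1 to compound 2 (0.84 log units; beyond the scatter), exchanges a much larger group and rests on a limit, so it offers only a loose guide. The expected change is therefore small, a 1.4-fold lower number from compound 2 to compound 3 (0.15 log units; within the scatter), with no clear shift beyond the scatter. The estimate for compound 3 is 5000 nM, with an expected range of 1500 nM to 15000 nM.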

Compound 3, solubility: <= 1000 nM
Compound 3 ended at the assay's limit; the forecaster's own chance of this, stated with the estimate: 15%; at least 5.0-fold (0.69 log units) between middle value and limit.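

In this assay, replacing the hydrogen on this oxygen with methyl, hydroxy to methoxy, gives an at least 7.0-fold lower number from compound 2 to compound 3 (0.84 log units; beyond the scatter). The earlier step exchanged a much larger group, whereas this one shows that a single added methyl at this position can move the number beyond the scatter. The value of compound 3, <= 1000 nM, is a limit, and the step between compound 1 and compound 3 cannot be read, as both values are limits: the limit of <= 1000 nM in this assay, at which 2 of the 3 values shown sit.

Open, from the compounds shown here alone, is whether an ethoxy group on this oxygen, or an amine in place of the hydroxy, would sit at this limit or nearer compound 2.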